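This account rests on a few compounds, and the source may have more. Where it says the series, first, only, none or still open, it means among the compounds named here.

Compound 1 `c1ccc(OCc2nc3c(OCCCN4CCCCC4)cccc3n2CCCC2CCN(CCC3CCCCC3)CC2)cc1` gives 0.285 nM in an in vitro assay on AV12 cells for binding affinity to Neuropeptide Y receptor type 1 (Homo sapiens); on this read-out higher numbers stand for weaker inhibition and lower numbers for stronger inhibition. Compound 2 `CN1CCC(CCCn2c(COc3ccccc3)nc3c(OCCCN4CCCCC4)cccc32)CC1` gives 1.62 nM in this assay. Compound 3 `O=C(CCN1CCC(CCCn2c(COc3ccccc3)nc3c(OCCCN4CCCCC4)cccc32)CC1)c1ccccc1` gives 0.112 nM in this assay.

All three share one core and differ only in what hangs from the amine nitrogen of the ring at the end of the chain. Compound 3 stands at the lowest number of the three: a 2.5-fold lower number from compound 1 to compound 3 (0.41 log units; beyond the scatter), and a 14-fold lower number from compound 2 to compound 3 (1.16 log units; beyond the scatter), so the benzoyl-bearing chain gives the strongest binding among these compounds.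

Compound 4 `O=C(CCCN1CCC(CCCn2c(COc3ccccc3)nc3c(OCCCN4CCCCC4)cccc32)CC1)c1ccccc1` extends that chain by one carbon: benzoylmethyl in place of benzoyl on a saturated chain carbon, two bonds along the chain from an amine nitrogen in a ring. Among the compounds with values here, no measured step changes only the length of this chain, so the closest guides are the modest step from compound 1 to compound 3 and the large step from compound 2 to compound 3, both of which show that the group here matters. A step of one carbon is a smaller change than either, and no direction is given by the data. The expected step is a 1.3-fold higher number from compound 3 to compound 4 (0.13 log units; within the scatter), within the scatter. Compound 4 is therefore estimated at 0.15 nM, in a range from 0.05 nM to 0.5 nM.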

Compound 4, inhibition constant: 0.132 nM
Beside the measured number, compound 4's estimate is 1.1-fold (0.06 log units) above it; low and high end bracket the measured number.
By their numbers in this assay, from the lowest: compounds 3 and 4 (each within the scatter of the next); then compound 1; then compound 2.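

Benzoylmethyl in place of benzoyl, on a saturated chain carbon two bonds along the chain from an amine nitrogen in a ring, gives a step within the scatter in this assay (a 1.2-fold higher number from compound 3 to compound 4 (0.07 log units; within the scatter)), so this position accepts one more chain carbon with no change that can be read. The longer chain also keeps the large advantage over the methyl group (a 12-fold lower number from compound 2 to compound 4 (1.09 log units; beyond the scatter)) and the modest advantage over the cyclohexyl-ended chain (a 2.2-fold lower number from compound 1 to compound 4 (0.33 log units; beyond the scatter)). No measurement is at hand to explain why the added carbon leaves the number within the scatter.

Within the data shown here, how far this tolerance runs remains open, since a chain longer than the one in compound 4 could hold or lose the binding. The compounds also leave open what the carbonyl contributes, which a plain phenylalkyl chain or an amide in its place would test.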